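Methyl in place of chloro on an aromatic carbon

A few compounds are considered here, and "the series" means these few. Any claim that something is new, unique, unknown or untested is made for them only; others in the source may bear on it.

Two compounds built on a shared core have so far been examined in a functional assay on SK-MEL-2 cells (Homo sapiens) for cytotoxicity; on this read-out higher numbers stand for weaker inhibition and lower numbers for stronger inhibition. Compound 1 (`Cc1ccc(S(=O)(=O)N2C(=O)NCC2c2ccccc2)cc1`) is reported only as a limit (> 316000 nM), not as a number. Within the data shown here, compound 2 (`Cc1ccc(C2CNC(=O)N2S(=O)(=O)c2ccc(Cl)cc2)cc1`) gives the only actual number in the set (255000 nM), so it is the single firm anchor for what follows.

Compound 3 (`Cc1ccc(C2CNC(=O)N2S(=O)(=O)c2ccc(C)cc2)cc1`) has not yet been measured. It departs from compound 2 by one change, methyl in place of chloro on an aromatic carbon, and the change sits para to a large group. Among the measured compounds shown here, no measured pair shows what this kind of swap does in this assay and the expectation therefore rests on compound 2 (255000 nM) and the small size of the change. No shift beyond the usual scatter is expected in either direction, and compound 3 may also come back as a limit instead of a number. The estimate amounts to a 1.1-fold higher number from compound 2 to compound 3 (0.04 log units; within the scatter) and no more than the usual scatter. For compound 3 the expected value is 280000 nM with an estimated range from 140000 nM to 500000 nM in this assay.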

Compound 3, half-maximal inhibitory concentration: 234000 nM
The estimate for compound 3 lay 1.2-fold (0.08 log units) above the measured number; the range from low to high includes it.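

In this assay, among these compounds, the swap from 4-chlorophenyl to 4-methylphenyl gives the first measured step at this position, a 1.1-fold lower number from compound 2 to compound 3 (0.04 log units; within the scatter), so on an aromatic carbon para to a large group, chloro and methyl cannot be told apart on this read-out. The second step, the addition of a methyl group to an aromatic ring, reads an at least 1.3-fold lower number from compound 1 to compound 3 (0.13 log units; that floor lies within the scatter), which also shows no separation beyond the scatter. That step is only a floor, since compound 1 is reported as a limit and not as a number: the limit of > 316000 nM in this assay, at which 1 of the 3 values shown sits.

The compounds shown leave open whether any group on this aromatic carbon can move the number beyond the usual scatter, as an amine, a carboxylic acid or a longer chain in place of the methyl might or might not. They also leave open whether the same swap of methyl for chloro would read alike on the other aromatic ring of the shared core, and how far the true number of compound 1 lies from that of compound 3.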